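A methyl-for-trifluoromethyl swap carried onto a second core

A few compounds are considered here, and "the series" means these few. Any claim that something is new, unique, unknown or untested is made for them only; others in the source may bear on it.

Measured compounds:
compound 1 `C=C1C(=O)[C@]23C[C@@]1(O)CC[C@H]2c1ccc(O)c(C)c1[C@@H]3Cn1cc(-c2ccc(C(F)(F)F)cc2)nn1` — 1440 nM
compound 2 `C=C1C(=O)[C@]23C[C@@]1(O)CC[C@H]2c1ccc(O)c(C)c1[C@@H]3Cn1cc(-c2ccc(C)cc2)nn1` — 920 nM
compound 3 `C=C1C[C@]23C[C@@]1(O)CC[C@@H]2c1cccc(C)c1[C@@H]3Cn1cc(-c2ccc(C(F)(F)F)cc2)nn1` — > 20000 nM

All three were tested in a functional assay on SMMC-7721 cells (Homo sapiens) for cytotoxicity, read by MTT assay, with a stated time of 4 days; a higher number here means a weaker inhibitor, a lower number a stronger inhibitor. In this assay compound 1 gives 1440 nM and compound 2 gives 920 nM. The two differ in one place, (methyl in place of trifluoromethyl on an aromatic carbon), and the step of a 1.6-fold lower number from compound 1 to compound 2 (0.19 log units; within the scatter) is small. For compound 3 this assay reports only a limit, > 20000 nM, so no number is known for it. Compound 3 sits on a different core from compound 1; the difference between the two cores is not broken down here.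

Compound 4 `C=C1C[C@]23C[C@@]1(O)CC[C@@H]2c1cccc(C)c1[C@@H]3Cn1cc(-c2ccc(C)cc2)nn1` is not yet measured. It stands to compound 3 as compound 2 stands to compound 1: the change is methyl in place of trifluoromethyl on an aromatic carbon, and the place of the change reads the same word for word, so this is the same change made a second time. The one earlier occurrence, from compound 1 to compound 2, moved the number within the scatter, and compound 3 sits at the limit of > 20000 nM in this assay, at which 1 of the 3 values shown sits. Among the compounds with values here, because the only precedent is a 1.6-fold lower number from compound 1 to compound 2 (0.19 log units; within the scatter), compound 4 is expected to stay close to compound 3, and a second limit is the most probable outcome. Compound 4 is expected to give about 25000 nM in this assay. The range expected for compound 4 runs from 10000 nM to 60000 nM. The expected step is a step that the limit leaves unreadable from compound 3 to compound 4.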

Compound 4, half-maximal inhibitory concentration: > 20000 nM
Compound 4: a limit, no number; the forecaster's own chance of this, stated with the estimate: 65%; the middle value lies beyond the limit too.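

In this assay compound 4 gives > 20000 nM, which is a limit and not a number. Within the data shown here, compound 3 also has only a limit, so no step between compound 3 and compound 4 can be read, and both stand at the same value: the limit of > 20000 nM in this assay, at which 2 of the 4 values shown sit. The compounds shown leave open how large the methyl-for-trifluoromethyl change is on the core of compound 3, or whether it has any effect there.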